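The source may report more compounds than this note shows. Statements on the series, on what has been measured and on what is new or still open speak of the compounds shown alone.

Of the compounds shown here, three built on one shared core have been measured in an assay on brain (strain C57BL6) for displacement of a labelled ligand from AP2-associated protein kinase 1 (Mus musculus), read by scintillation counting, with a stated time of 1 h; on this read-out lower numbers stand for stronger inhibition and higher numbers for weaker inhibition. Compound 1 `CC(=O)Nc1cc(-c2ccc(OC[C@@H](N)CC(C)C)c(F)c2)ccn1` carries a fluoro group on the ring that bears the amine side chain, and in this assay compound 1 gives 0.52 nM. Compound 2 `COC(=O)Nc1cc(-c2ccc(OC[C@@](C)(N)CC(C)C)c(F)c2)ccn1` differs in more than one place, with a methyl carbamate instead of the acetamide and a further methyl on the side chain; compound 2 gives 0.2 nM. Compound 3 `CC(=O)Nc1cc(-c2ccc(OC[C@@H](N)CC(C)C)c(C)c2)ccn1` keeps the acetamide of compound 1 but has methyl where compound 1 has fluoro; compound 3 gives 0.08 nM, the lowest number of the three and therefore the strongest binder among them, with compound 2 nearest to it and compound 1 furthest away.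

Among the measured compounds shown here, only one single-change step is available: a 6.5-fold lower number from compound 1 to compound 3 (0.81 log units; beyond the scatter). Compound 4 `CC(=O)Nc1cc(-c2ccc(OC[C@@H](N)CC(C)C)c(Cl)c2)ccn1` is the next compound to be measured, and it differs from compound 3 in one way: chloro in place of methyl on an aromatic carbon. For the measured compounds named here, no measured pair sets chloro against methyl or against fluoro at this position, so the fluoro-to-methyl step is the sole guide. Since both neighbours of this change are known, compound 4 is expected to land between them, as a modest step of a 1.9-fold higher number from compound 3 to compound 4 (0.27 log units; within the scatter). Compound 4 is therefore estimated at 0.15 nM, within a range from 0.05 nM to 0.5 nM.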

Compound 4, inhibition constant: 0.06 nM
Beside the measured number, compound 4's estimate is 2.5-fold (0.40 log units) above it; the range from low to high includes it.
By their numbers in this assay, from the lowest: compounds 4 and 3 (each within the scatter of the next); then compound 2; then compound 1.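

In this assay, the ring position ortho to the (2-amino-4-methylpentyl)oxy group now has three groups compared on an otherwise unchanged structure, which turns a single fluoro-to-methyl comparison into a small series. Chloro in place of methyl gives a 1.3-fold lower number from compound 3 to compound 4 (0.12 log units; within the scatter) and so leaves the number within the usual scatter, while chloro in place of fluoro gives an 8.7-fold lower number from compound 1 to compound 4 (0.94 log units; beyond the scatter) and is a real difference, so at this position fluoro is separated from both of the other groups, and methyl and chloro cannot be told apart. Nothing here explains why these two groups behave alike or why fluoro stands apart, as no supporting measurement bears on the result.

Among the compounds shown here, with only three groups tested at this position, it remains open how a bromo, a methoxy or a plain hydrogen would compare with them. For the compounds shown here, it is also open whether chloro would give a similar step when paired with the methyl carbamate and the extra side-chain methyl of compound 2, since no single-change pair shows this.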